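Urea aryl swap in the benzofuran pyrazoline series

The source may hold more compounds than are shown below. What is called first, only, known or untested is meant among the compounds shown, and "the series" means these compounds.

Compound 3 `COc1cc(NC(=O)N2N=C(c3cc4ccccc4o3)CC2c2ccc(O)c(OC)c2)ccc1O` gives the lowest number of the three measured, at 12000000 nM in a functional assay on microsomes from liver (Rattus norvegicus, strain Wistar) for inhibition, with a stated time of 15 min; on this read-out higher numbers stand for weaker inhibition and lower numbers for stronger inhibition. Compound 2 `COc1ccc(NC(=O)N2N=C(c3cc4ccccc4o3)CC2c2ccc(O)c(OC)c2)cc1` gives 29000000 nM in this assay, and compound 1 `COc1cc(C2CC(c3cc4ccccc4o3)=NN2C(=O)Nc2ccccc2)ccc1O` gives 116000000 nM. Compound 4 `COc1cc(C2CC(c3cc4ccccc4o3)=NN2C(=O)Nc2ccc(Cl)cc2)ccc1O` differs from compound 3 by 4-chlorophenyl in place of 4-hydroxy-3-methoxyphenyl on an amide-type nitrogen. Among the compounds with values here, two measured steps bear on this: a 9.7-fold lower number from compound 1 to compound 3 (0.99 log units; beyond the scatter) and a 2.4-fold lower number from compound 2 to compound 3 (0.38 log units; beyond the scatter), both moving toward the 4-hydroxy-3-methoxyphenyl group; taking that group away points the other way, and nothing measured here speaks to 4-chlorophenyl itself. A higher number is therefore expected for compound 4, with a 4.2-fold higher number from compound 3 to compound 4 (0.62 log units; beyond the scatter) as the estimated step. Compound 4 is estimated at 50000000 nM, within 15000000 nM to 150000000 nM.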

Compound 4, half-maximal inhibitory concentration: 121000000 nM
Estimate against measurement, compound 4: 2.4-fold (0.38 log units) below; measured number inside the range.
By their numbers in this assay, from the lowest: compound 3; then compound 2; then compounds 1 and 4 (each within the scatter of the next).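

In this assay, chloro and hydrogen on the aromatic carbon cannot be told apart (a 1.0-fold higher number from compound 1 to compound 4 (0.02 log units; within the scatter)). Only the oxygen-bearing groups among those compared give lower numbers: chloro in place of methoxy raises the number (a 4.2-fold higher number from compound 2 to compound 4 (0.62 log units; beyond the scatter)), and 4-chlorophenyl in place of 4-hydroxy-3-methoxyphenyl raises it further (a 10-fold higher number from compound 3 to compound 4 (1.00 log units; beyond the scatter)).

From the compounds shown here alone, whether 4-hydroxyphenyl, an amine or a carboxylic acid on this aromatic ring would give a lower number remains open. No available evidence accounts for these steps.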